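Swapping the Fluorophenyl for a Methyl Ester

The compounds below may be only part of what the source reports. "The series", "measured", "known", "first", "only" and "open" are said of these compounds alone.

Compound 3 `Cc1[nH]n(-c2nc3ccccc3[nH]2)c(=O)c1Cc1ccc(F)cc1` is the only one of the three measured compounds with a number: in an assay on isolated protein for inhibition of alpha-ketoglutarate-dependent dioxygenase alkB homolog 3 (Homo sapiens), read by polymerase chain reaction, with a stated time of 1 h (a lower number here means a stronger inhibitor, a higher number a weaker inhibitor), compound 3 gives 600 nM. Compound 1 `Cc1[nH]n(-c2nc3ccccc3[nH]2)c(=O)c1Cc1ccc(Cl)cc1` reaches only a limit of the assay, > 10000 nM, in this assay. Compound 2 `Cc1[nH]n(-c2nc3ccccc3[nH]2)c(=O)c1Cc1ccc(Cl)cc1Cl` likewise reaches only the limit of > 10000 nM in this assay. Both sit at the limit of > 10000 nM in this assay, at which 2 of the 3 values shown sit, so the step that the two limits leave unreadable from compound 1 to compound 2 cannot be read. The steps of an at least 16-fold lower number from compound 1 to compound 3 (1.22 log units; beyond the scatter) and an at least 16-fold lower number from compound 2 to compound 3 (1.22 log units; beyond the scatter) show that a change of halogen on the ring bound to the saturated chain carbon shifts the number by a large amount. Compound 4 `COC(=O)Cc1c(C)[nH]n(-c2nc3ccccc3[nH]2)c1=O` differs from compound 3 by methoxycarbonyl in place of 4-fluorophenyl on a saturated chain carbon bound to an aromatic carbon. Within the data shown here, no measured step tests this change, which removes that ring altogether. The steps of an at least 16-fold lower number from compound 1 to compound 3 (1.22 log units; beyond the scatter) and an at least 16-fold lower number from compound 2 to compound 3 (1.22 log units; beyond the scatter) show how strongly the number depends on this ring. Compound 4 is therefore expected to be weaker, by an estimated 8.3-fold higher number from compound 3 to compound 4 (0.92 log units; beyond the scatter). Compound 4 is estimated at 5000 nM, within 1000 nM to 20000 nM, with a real chance that only a limit is reported.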

Compound 4, half-maximal inhibitory concentration: 4300 nM
Compound 4: the middle estimate sits 1.2-fold (0.07 log units) above what was measured, and the stated range covers the measured number.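

The 4-fluorophenyl ring is not needed for a measurable number in this assay: methoxycarbonyl, which has no ring, still gives one, though at a clear cost (a 7.2-fold higher number from compound 3 to compound 4 (0.86 log units; beyond the scatter)). The same swap does better than the 4-chlorophenyl ring (an at least 2.3-fold lower number from compound 1 to compound 4 (0.36 log units; beyond the scatter)) and the 2,4-dichlorophenyl ring (an at least 2.3-fold lower number from compound 2 to compound 4 (0.36 log units; beyond the scatter)), so among these compounds only 4-fluorophenyl beats the ringless ester, and the two chlorinated rings do worse than having no ring at all. Both of those steps start from a limit of the assay, not from a number: the limit of > 10000 nM in this assay, at which 2 of the 4 values shown sit.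

From the compounds shown here alone, it remains open whether the ester itself contributes anything, or whether a carboxylic acid, an amide or a simple ethyl chain at this place would do as well. Also open, going by these compounds, is whether a plain unsubstituted phenyl ring would match 4-fluorophenyl.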